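The compounds below may be only part of what the source reports. "The series", "measured", "known", "first", "only" and "open" are said of these compounds alone.

Measured compounds:
compound 1 `O=S(=O)(NCCCNCc1cccc2ccccc12)c1cc(C(F)(F)F)cc(C(F)(F)F)c1` — 2800 nM
compound 2 `O=S(=O)(NCCCCCCNCc1ccc(Br)cc1)c1ccccc1Cl` — 13700 nM
compound 3 `CC(C)(C)c1ccc(S(=O)(=O)NCCCCCCNCc2ccc(Br)cc2)cc1` — 2970 nM

In a functional assay on MIA PaCa-2 cells (Homo sapiens) for inhibition, read by MTT assay, with a stated time of 72 h (on this read-out lower numbers stand for stronger inhibition of growth and higher numbers for weaker inhibition of growth), compound 2 gives 13700 nM, the highest of the three numbers. Compound 3 gives 2970 nM and compound 1 gives 2800 nM; both stand lower than compound 2 by more than the scatter, so compound 2 is the weakest growth inhibitor of the three.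

Compound 4 `O=[N+]([O-])c1ccccc1S(=O)(=O)NCCCCCCNCc1ccc(Br)cc1` is the next compound and differs from compound 2 in one place: nitro in place of chloro on an aromatic carbon. Among the measured compounds shown here, no pair of measured compounds shows this same change, so nothing in the data sets the size of the step. In this assay a small step is expected, at most modestly downward and possibly within the scatter, as a 1.7-fold lower number from compound 2 to compound 4 (0.23 log units; within the scatter). Compound 4 is therefore estimated at 8000 nM, with a range from 2500 nM to 25000 nM.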

Compound 4, concentration for 50% growth inhibition: 11700 nM
Compound 4: the middle estimate sits 1.5-fold (0.17 log units) below what was measured, and the stated range covers the measured number.
By their numbers in this assay, from the lowest: compounds 1 and 3 (each within the scatter of the next); then compounds 4 and 2 (each within the scatter of the next).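

At this position, ortho to a large group, this assay gives a 1.2-fold lower number from compound 2 to compound 4 (0.07 log units; within the scatter), so 2-chlorophenyl and 2-nitrophenyl are not told apart by this read-out. Among the compounds shown here, three heavy atoms and two hydrogen-bond acceptors enter here with no change beyond the scatter, which the earlier compounds could not show. No supporting measurement bears on why the two groups read alike. Going by these compounds, what remains open is how an amine or a carboxylic acid on this aromatic carbon would read. A longer alkyl chain at this place is equally unresolved.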